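The source may report more compounds than this note shows. Statements on the series, on what has been measured and on what is new or still open speak of the compounds shown alone.

In a functional assay on U-87MG ATCC cells (Homo sapiens) for antiproliferative activity, with a stated time of 3 days (a higher number here means that more compound is needed for the effect, a lower number that less compound is needed), compound 3 (`Cc1ccc(CNCc2ccc(O)c3ncccc23)cc1`) gives > 10 uM, which is a limit of the assay and not a number. Compound 1 (`Oc1ccc(CN(Cc2ccccc2C(F)(F)F)Cc2ccc(O)c3ncccc23)c2cccnc12`) gives < 0.2 uM, also a limit. Compound 2 (`Oc1ccc(CN(Cc2cccs2)Cc2ccc(O)c3ncccc23)c2cccnc12`) gives < 0.2 uM, likewise a limit. Compound 1 and compound 2 each carry the core of compound 3 a second time on their nitrogen. Going by the values given here, the one measured step among them, a step that the two limits leave unreadable from compound 1 to compound 2, has no readable size and lies at another place in the structure, so it offers no guide to the change at hand.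

Compound 4 (`Oc1ccc(CNCc2ccc(C(F)(F)F)cc2)c2cccnc12`) differs from compound 3 in one group: trifluoromethyl in place of methyl on an aromatic carbon, para to a large group. Among the compounds with values here, no measured step bears on this place, so no step beyond the scatter is expected in this assay, in either direction. The expectation rests on the limit of compound 3, > 10 uM, alone. Compound 4 is expected at 10 uM, with an estimated range of 3 uM to 30 uM. That estimate means an expected step of a number no higher from compound 3 to compound 4 (the limit leaves the size open).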

Compound 4, concentration for half-maximal effect: > 10 uM
Compound 4: a limit, no number; the forecaster's own chance of this, stated with the estimate: 55%; the middle value sits exactly at the limit.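

In this assay compound 3 and compound 4 each give only a limit and not a number, and no step can be read between them. The compounds shown leave open how far either lies past that limit, and whether trifluoromethyl in place of methyl changes the result at all.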